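The source may hold more compounds than are shown below. What is called first, only, known or untested is meant among the compounds shown, and "the series" means these compounds.

Measured compounds:
Compound 1, `C/C(=C\c1ccc(NC(=O)Nc2ccc(Cl)c(C(F)(F)F)c2)cc1)C(=O)NC(C)c1ccccc1`: > 50000 nM
Compound 2, `CC(NC(=O)c1cccc(-c2ccc(NC(=O)Nc3ccc(Cl)c(C(F)(F)F)c3)cc2)c1)c1ccccc1`: 5240 nM

Among the compounds with values here, in a functional assay on MX1 cells (Homo sapiens) for inhibition, read by MTT assay, with a stated time of 120 h (a higher number here means a weaker inhibitor, a lower number a stronger inhibitor), compound 2 gives 5240 nM, the only numerical value among the two measured compounds. Compound 1, which carries the same urea end but a different linker, returns a limit in this assay, > 50000 nM, and so no number at all. That limit is the one described in the limit of > 50000 nM in this assay, at which 1 of the 2 values shown sits. Compound 2 therefore stands alone as a measured point, with nothing beside it to compare against within the scatter.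

Compound 3, `CNC(=O)c1cccc(-c2ccc(NC(=O)Nc3ccc(Cl)c(C(F)(F)F)c3)cc2)c1`, has not yet been measured in this assay. It differs from compound 2 in one place: methyl in place of 1-phenylethyl on an amide-type nitrogen. The shared core with its biaryl and urea remains untouched, and only the substituent on the amide nitrogen shrinks. Within the data shown here, no measured pair in the set carries this particular change, so its effect is not known from the data.

The expectation for compound 3 is a weaker inhibitor than compound 2, with a step of a 2.9-fold higher number from compound 2 to compound 3 (0.46 log units; beyond the scatter), clearly beyond the scatter. The estimated value for compound 3 in this assay is 15000 nM, with a range from 4000 nM to 50000 nM.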

Compound 3, half-maximal inhibitory concentration: > 50000 nM
Compound 3: no number, only a limit; the forecaster's own chance of this, stated with the estimate: 25%; middle value at least 3.3-fold (0.52 log units) away from the limit.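

In this assay, this position on the amide-type nitrogen proves sensitive to the substituent: methyl in place of 1-phenylethyl gives an at least 9.5-fold higher number from compound 2 to compound 3 (0.97 log units; beyond the scatter). Compound 3 gives > 50000 nM, which is a limit of the assay and not a number, so the full size of the step cannot be read. Compound 2 therefore remains the only compound shown with a numerical value, while the other readings sit at the same limit: the limit of > 50000 nM in this assay, at which 2 of the 3 values shown sit.

The step removes the six-membered aromatic ring and seven carbons' worth of the 1-phenylethyl group in one move, so the compounds shown do not separate what the ring contributes from what the rest of the group contributes. Going by these compounds, it also remains open whether a benzyl group, a cyclohexyl group or a longer alkyl chain on the same nitrogen would keep a numerical value in this assay, or whether an amine or a carboxylic acid carried on that substituent would be tolerated.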